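Swapping a methoxyphenyl for a chlorophenyl: expected clearance

The compounds below may be only part of what the source reports. "The series", "measured", "known", "first", "only" and "open" are said of these compounds alone.

Measured compounds:
Compound 1 `COc1ccc(-c2c(S(=O)(=O)c3cc(F)cc(F)c3)cnc3c(F)cccc23)cc1`: 2.59 mL/min
Compound 2 `COc1cccc(-c2c(S(=O)(=O)c3cccc(C#N)c3)cnc3cc(F)ccc23)c1`: 1.83 mL/min
Compound 3 `O=S(=O)(c1cccc(F)c1)c1cnc2c(F)cccc2c1-c1ccc(Cl)cc1`: 0.62 mL/min

The read-out in every case is an ADME assay on microsomes from liver (Homo sapiens) for metabolic stability, tested at 2.5 uM; on this read-out higher numbers stand for fast clearance and lower numbers for slow clearance. Compound 1 has the highest number of the three. Its nearest neighbour is compound 2, whose number lies within the usual scatter of compound 1, so no order between those two can be claimed. Compound 3 sits furthest away, and that gap is beyond the scatter, so compound 3 is cleared more slowly than compound 1.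

Compound 4 `O=S(=O)(c1cc(F)cc(F)c1)c1cnc2c(F)cccc2c1-c1cccc(Cl)c1` has not yet been measured in this assay. Relative to compound 1 the change is 3-chlorophenyl in place of 4-methoxyphenyl on an aromatic carbon. Among the measured compounds shown here, no measured pair isolates this change, so its effect is not directly known. Compound 3, which also bears a chlorophenyl group on the shared core, gives 0.62 mL/min, and this is the only hint available. On that basis a lower number is expected for compound 4, and the step of a 2.6-fold lower number from compound 1 to compound 4 (0.41 log units; beyond the scatter) is estimated to reach beyond the scatter. Compound 4 is expected to give about 1 mL/min, with a range from 0.4 mL/min to 2.5 mL/min.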

Compound 4, intrinsic clearance in a liver preparation (reported as CLH), per the amount of preparation that the assay uses: 0.64 mL/min
Beside the measured number, compound 4's estimate is 1.6-fold (0.19 log units) above it; measured number inside the range.
By their numbers in this assay, from the lowest: compounds 3 and 4 (each within the scatter of the next); then compounds 2 and 1 (each within the scatter of the next).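

In this assay, among the compounds shown here, the two compounds form the first pair that differs in one place: 3-chlorophenyl in place of 4-methoxyphenyl on the shared core gives a 4.0-fold lower number from compound 1 to compound 4 (0.61 log units; beyond the scatter) and is the only isolated change at this position. The earlier compounds shown here differed from one another in more than one place, so none of them could tie a shift in clearance to this position alone. No measurement shown here accounts for the step.

For the compounds shown here, the single swap replaces the substituent and moves it on the phenyl ring at once, so it remains open whether the step belongs to the chlorine, to its place on the ring, or to the loss of the methoxy group. Nor do the compounds show how a plain phenyl or an amine-bearing phenyl would behave at this position.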